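This account rests on a few compounds, and the source may have more. Where it says the series, first, only, none or still open, it means among the compounds named here.

Measured compounds:
compound 1, `COc1ccccc1OC[C@@H]1CCc2cc([C@H]3CC[C@](N)(CO)C3)ccc2C1`, 85%
compound 2, `N[C@]1(CO)CC[C@H](c2ccc3c(c2)CC[C@@H](COc2ccc(F)cc2)C3)C1`, 74%
compound 3, `COc1ccc(OC[C@@H]2CCc3cc([C@H]4CC[C@](N)(CO)C4)ccc3C2)cc1`, 47%

These three share one core and differ only in the aryl group hung on the oxygen. In a functional assay on the whole organism (strain Lewis) with Rattus norvegicus as the target, with a stated time of 24 h, at a dose of 2 mg/kg by the oral route (a higher number here means more inhibition at the dose given (going by the name of the read-out), a lower number less inhibition), compound 3 gives the lowest of the three numbers; compound 2 sits above it by a number 27 percentage points lower from compound 2 to compound 3 (beyond the scatter) and compound 1 above it by a number 38 percentage points lower from compound 1 to compound 3 (beyond the scatter), both gaps beyond the scatter.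

Compound 4, `COc1ccccc1SC[C@@H]1CCc2cc([C@H]3CC[C@](N)(CO)C3)ccc2C1`, is not yet measured. It differs from compound 3 in one place: (2-methoxyphenyl)sulfanyl in place of 4-methoxyphenoxy on a saturated chain carbon bound to a saturated ring carbon. This change has two parts. The methoxy moves back to where it stands in compound 1, and the oxygen link becomes a sulfur link. The first part is the reverse of the step of a number 38 percentage points lower from compound 1 to compound 3 (beyond the scatter), which was large, so a large rise in this assay is expected for compound 4 because a number 38 percentage points lower from compound 1 to compound 3 (beyond the scatter) ran downhill from the 2-methoxyphenyl pattern. Among the measured compounds shown here, no measured step speaks to the oxygen-to-sulfur swap, so the estimate carries a wide range. For compound 4 the expected step is a number 28 percentage points higher from compound 3 to compound 4 (beyond the scatter), giving an estimate of 75%, between 55% and 92%.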

Compound 4, a percentage reported as inhibition, in the whole organism at one dose (the size of the read-out at that dose, not a potency): 78%
The estimate for compound 4 lay 3 percentage points below the measured number, and the stated range covers the measured number.
By their numbers in this assay, from the lowest: compound 3; then compounds 2, 4 and 1 (each within the scatter of the next, the first and the last beyond it).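

In this assay, a sulfur link in place of the oxygen link, with the 2-methoxyphenyl group kept, gives a number 7 percentage points lower from compound 1 to compound 4 (within the scatter), so at this position sulfur can stand in for oxygen with no shift that rises above the scatter. The combined change gives a number 31 percentage points higher from compound 3 to compound 4 (beyond the scatter), while the comparison with the fluorinated ether gives a number 4 percentage points higher from compound 2 to compound 4 (within the scatter). Compound 3, which carries 4-methoxyphenoxy, therefore stands beyond the scatter from all three other compounds, and the sulfur link does not take compound 4 out of the range of compound 1 or compound 2.

No measurement at hand accounts for these numbers. From the compounds shown here alone, whether an amine in place of the sulfur link, or a 4-methoxyphenyl group on the sulfur, would keep the number in this assay stays open.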